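The source may hold more compounds than are shown below. What is called first, only, known or untested is meant among the compounds shown, and "the series" means these compounds.

Compound 1 `O=c1sc2ccccc2n1CCCN1CCCCCC1`: 4.1 nM
Compound 2 `CCC(=O)c1ccc2c(c1)sc(=O)n2CCCN1CCCCCC1`: 3.7 nM
Compound 3 `CCC(=O)c1ccc2c(c1)sc(=O)n2CCCCN1CCCCCC1`: 10.3 nM

In an assay on cell membranes for displacement of a labelled ligand from Sigma non-opioid intracellular receptor 1 (Rattus norvegicus) (a lower number here means a stronger inhibitor, a higher number a weaker inhibitor), compound 2 gives the lowest of these three numbers, though compound 1 lies within the scatter of it (a 1.1-fold lower number from compound 1 to compound 2 (0.04 log units; within the scatter)), while compound 3 stands further off (a 2.8-fold higher number from compound 2 to compound 3 (0.44 log units; beyond the scatter)). Compound 4 `CCCC(=O)c1ccc2c(c1)sc(=O)n2CCCN1CCCCCC1` differs from compound 2 by methyl in place of hydrogen on a saturated chain carbon, two bonds along the chain from a carbonyl carbon. Within the data shown here, the step that bears on this is the one from compound 1 to compound 2, where the whole propanoyl group entered at the aromatic carbon and the number moved only within the scatter: a 1.1-fold lower number from compound 1 to compound 2 (0.04 log units; within the scatter). Extending that same group further out is expected to matter less still, so no step beyond the scatter is expected: a 1.2-fold higher number from compound 2 to compound 4 (0.09 log units; within the scatter). For compound 4 the expected value in this assay is 4.5 nM, with a range from 2 nM to 10 nM.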

Compound 4, inhibition constant: 2.6 nM
The estimate for compound 4 lay 1.7-fold (0.24 log units) above the measured number, within the range that was stated.
By their numbers in this assay, from the lowest: compounds 4, 2 and 1 (each within the scatter of the next); then compound 3.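

In this assay, one added methyl at this chain carbon keeps the number within the scatter (a 1.4-fold lower number from compound 2 to compound 4 (0.15 log units; within the scatter)), so the side chain can grow beyond propanoyl without a readable shift. Compared with compound 1, which has hydrogen at that aromatic carbon, propylcarbonyl also stays within the scatter (a 1.6-fold lower number from compound 1 to compound 4 (0.20 log units; within the scatter)). No measurement at hand gives a reason for this flat result. Still open, on these data alone, is whether a much longer chain, or an amine or carboxylic acid at the end of this chain, would keep the number there. Also open, as far as these compounds go, is how propylcarbonyl behaves on the longer azepane-bearing chain of compound 3.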